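Sulfonyl Capping of the Ring Nitrogen in Compound 1

The source may report more compounds than this note shows. Statements on the series, on what has been measured and on what is new or still open speak of the compounds shown alone.

Compound 1 `c1ccc(Sc2ncnc3ncn(C4CNc5ccccc5CO4)c23)cc1` stands at the high end of the two numbers in a functional assay on MCF7 cells (Homo sapiens) for antiproliferative activity; a higher number here means a weaker inhibitor, a lower number a stronger inhibitor: compound 1 gives 48900 nM, while compound 3 `Clc1ncnc2c1ncn2C1COc2ccccc2CO1` gives 1250 nM, a gap well beyond the scatter. Compound 2 `COC(CN(c1ccccc1CO)S(=O)(=O)c1ccccc1[N+](=O)[O-])n1cnc2c(Cl)ncnc21` has several entries, 11300 nM; 3250 nM (2 entries), and this spread the several entries of compound 2 in this assay, 11300 nM; 3250 nM (2 entries) shows how far repeats of one compound can differ. Compound 4 `O=[N+]([O-])c1ccccc1S(=O)(=O)N1CC(n2cnc3ncnc(Sc4ccccc4)c32)OCc2ccccc21` remains unmeasured and differs from compound 1 in one place: (2-nitrophenyl)sulfonyl in place of hydrogen on a nitrogen on an aromatic ring in a ring. For the measured compounds named here, no step between measured compounds isolates this change; compound 2 carries the same (2-nitrophenyl)sulfonyl group on a nitrogen but differs elsewhere too. Compound 4 is expected to land somewhat lower than compound 1, with a step of a 2.4-fold lower number from compound 1 to compound 4 (0.39 log units; beyond the scatter) that may still sit within the scatter. The estimate for compound 4 is 20000 nM, ranging from 4000 nM to 100000 nM.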

Compound 4, half-maximal inhibitory concentration: 2590 nM
Beside the measured number, compound 4's estimate is 7.7-fold (0.89 log units) above it; measured number outside the range, below it.
By their numbers in this assay, from the lowest: compound 3; then compound 4; then compound 1.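

In this assay, (2-nitrophenyl)sulfonyl in place of hydrogen on this ring nitrogen gives a 19-fold lower number from compound 1 to compound 4 (1.28 log units; beyond the scatter), so a large group is accepted at this position and the hydrogen is not required for activity. This is the first step among the compounds shown that reads this position directly. The step is also wider than the gap between repeats of a single compound: the several entries of compound 2 in this assay, 11300 nM; 3250 nM (2 entries)

From the compounds shown here alone, whether a smaller methylsulfonyl or an acetyl group on this nitrogen would give a similar step remains open. So does the contribution of the nitro group within the (2-nitrophenyl)sulfonyl.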